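A Fluorine on the Fused Ring of Compound 1

The source may hold more compounds than are shown below. What is called first, only, known or untested is meant among the compounds shown, and "the series" means these compounds.

Compound 1 `NC(=O)[C@@H](c1ccccc1)N(C(=O)c1ccccc1)[C@@H]1CCc2ccccc21` is the stronger of the two measured compounds: in an assay on HEK293T cells for antagonist activity at transient receptor potential cation channel subfamily M member 8 (Homo sapiens), read by fluorescence and calcium flux, with a stated time of 60 min (a lower number here means a stronger inhibitor, a higher number a weaker inhibitor), compound 1 gives 270 nM. Compound 2 `NC(=O)[C@@H](c1ccccc1)N(C(=O)c1ccccc1)[C@@H]1CCc2ncccc21` gives 19500 nM in this assay, and the step of a 72-fold higher number from compound 1 to compound 2 (1.86 log units; beyond the scatter) shows how much a single change within the fused ring on the amide-type nitrogen can cost. Compound 3 `NC(=O)[C@@H](c1ccccc1)N(C(=O)c1ccccc1)[C@@H]1CCc2c(F)cccc21` keeps that fused ring as in compound 1 and differs from it only by fluoro in place of hydrogen on an aromatic carbon. Within the data shown here, no measured step tests a fluoro substituent; the one measured step exchanges a ring carbon for a ring nitrogen, a different kind of change, so it gives no direct guidance. Adding one fluorine is a far smaller alteration than that exchange, so only a modest shift is expected: compound 3 is estimated at 300 nM, with a likely range of 100 nM to 900 nM, an expected step of a 1.1-fold higher number from compound 1 to compound 3 (0.05 log units; within the scatter) within the scatter.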

Compound 3, half-maximal inhibitory concentration: 120 nM
Estimate against measurement, compound 3: 2.5-fold (0.40 log units) above; the measured number falls inside the stated range.
By their numbers in this assay, from the lowest: compound 3; then compound 1; then compound 2.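

Fluoro in place of hydrogen on this aromatic carbon gives a stronger inhibitor in this assay, with a 2.3-fold lower number from compound 1 to compound 3 (0.35 log units; beyond the scatter). Among these compounds, the step is modest, but it is the first measured gain from a change to this six-membered aromatic ring: the exchange of a ring carbon for a ring nitrogen went the other way, with a 72-fold higher number from compound 1 to compound 2 (1.86 log units; beyond the scatter). The ring can therefore be altered with a gain as well as with a heavy loss, although nothing shown gives a measured reason for the lower number.

Going by these compounds, whether the gain is particular to fluoro or would also appear with chloro, methyl or methoxy on the same carbon remains open. Also open, on these data alone, is whether fluoro on another aromatic carbon of this ring would give a similar step.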